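Methyl for hydrogen on the aromatic carbon of compound 2

A few compounds are considered here, and "the series" means these few. Any claim that something is new, unique, unknown or untested is made for them only; others in the source may bear on it.

Measured in a functional assay on L1210 cells (Mus musculus); a lower number here means a stronger inhibitor, a higher number a weaker inhibitor:
- compound 1, `N#C[C@]1(O)[C@H](O)[C@@H](CO)O[C@@H](n2cc(F)c(O)nc2=O)[C@@H]1O`, gives 1900 nM
- compound 2, `N#C[C@]1(O)[C@H](O)[C@@H](CO)O[C@@H](n2ccc(O)nc2=O)[C@@H]1O`, gives 417000 nM

Within the data shown here, compound 2 stands with the highest number of the two measured compounds; its nearest neighbour is compound 1, and the step of a 220-fold higher number from compound 1 to compound 2 (2.34 log units; beyond the scatter) separates them, a large move for the single change of hydrogen in place of fluoro on an aromatic carbon.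

Compound 3, `Cc1cn([C@@H]2O[C@H](CO)[C@@H](O)[C@@](O)(C#N)[C@H]2O)c(=O)nc1O`, is not yet measured. It differs from compound 2 by methyl in place of hydrogen on an aromatic carbon, that is, on the same aromatic carbon that carries fluoro in compound 1 and hydrogen in compound 2.

Among the measured compounds shown here, the only measured step that bears on this position is a 220-fold higher number from compound 1 to compound 2 (2.34 log units; beyond the scatter), which shows the ring carbon substituent matters greatly in this assay. For the measured compounds named here, no measured pair shows methyl there, so the size of the methyl step can only be guessed from the fact that the position is sensitive. A step in this assay of moderate size toward a lower number is expected for compound 3, a 4.2-fold lower number from compound 2 to compound 3 (0.62 log units; beyond the scatter). Compound 3 is estimated at 100000 nM, with a range from 20000 nM to 500000 nM.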

Compound 3, half-maximal inhibitory concentration: 539000 nM
The estimate for compound 3 lay 5.4-fold (0.73 log units) below the measured number, outside the stated range (above it).
By their numbers in this assay, from the lowest: compound 1; then compounds 2 and 3 (each within the scatter of the next).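

In this assay the place that looked sensitive from fluoro and hydrogen alone turns out to be sensitive in a narrower way: a 1.3-fold higher number from compound 2 to compound 3 (0.11 log units; within the scatter), so methyl on this aromatic carbon, ortho to a hydroxy group, cannot be told apart from hydrogen. The other new step, a 280-fold higher number from compound 1 to compound 3 (2.45 log units; beyond the scatter), is large, as is a 220-fold higher number from compound 1 to compound 2 (2.34 log units; beyond the scatter), which leaves compound 1 alone at the low end of the series, while hydrogen and methyl sit together at the high end; among these three compounds, therefore, the large move goes with fluoro specifically and not with simply having a group other than hydrogen on this carbon. Nothing measured on these compounds accounts for the difference between fluoro and the other two substituents.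

From the compounds shown here alone, whether chloro, bromo, an amine or a longer chain such as ethyl on this carbon would follow fluoro or fall with hydrogen and methyl remains open. Going by these compounds, all three compounds share the same nitrile on the core, so it is also open whether the large fluoro step persists when that nitrile is replaced by another group, such as a carboxylic acid.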